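Methoxy count on the aryl ring and antiproliferative potency

This account rests on a few compounds, and the source may have more. Where it says the series, first, only, none or still open, it means among the compounds named here.

Of the compounds shown here, three have been measured in a functional assay on MDA-MB-231 cells (Homo sapiens) for antiproliferative activity, read by MTT assay, with a stated time of 48 h; a lower number here means a stronger inhibitor, a higher number a weaker inhibitor. Compound 1 `COc1cc(/C=N/c2c(C#N)ncn2-c2ccc(F)cc2)cc(OC)c1OC` gives 18700 nM. Compound 2 `COc1ccc(/C=N/c2c(C#N)ncn2-c2ccc(F)cc2)cc1OC` gives 4270 nM. Compound 3 `COc1ccc(/C=N/c2c(C#N)ncn2Cc2ccc(F)cc2)cc1OC` gives 10500 nM.

Two steps connect these. From compound 2 to compound 1 the change is methoxy in place of hydrogen on an aromatic carbon, and it brings a 4.4-fold higher number from compound 2 to compound 1 (0.64 log units; beyond the scatter). From compound 2 to compound 3 the core changes by 4-fluorobenzyl in place of 4-fluorophenyl on an aromatic nitrogen, with a 2.5-fold higher number from compound 2 to compound 3 (0.39 log units; beyond the scatter). Compound 3 and compound 1 are within the scatter of each other, so no order between them is claimed.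

Compound 4 `COc1ccc(/C=N/c2c(C#N)ncn2Cc2ccc(F)cc2)c(OC)c1OC` is not yet measured in this assay. It differs from compound 3 by methoxy in place of hydrogen on an aromatic carbon. Among the measured compounds shown here, this is the same kind of change as the one from compound 2 to compound 1, though the surroundings differ: in compound 1 the entering methoxy sits meta to a large group, ortho to a methoxy group and meta to a methoxy group, whereas in compound 4 it sits ortho to a large group, ortho to a methoxy group and meta to a methoxy group. The cores also differ by 4-fluorobenzyl in place of 4-fluorophenyl on an aromatic nitrogen.

For the measured compounds named here, for compound 4 a step of a 3.8-fold higher number from compound 3 to compound 4 (0.58 log units; beyond the scatter) is expected, resting on the weakening seen in compound 1 at a 4.4-fold higher number from compound 2 to compound 1 (0.64 log units; beyond the scatter) and on the single occurrence of that change here. The estimate for compound 4 in this assay is 40000 nM, expected to lie between 15000 nM and 110000 nM.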

Compound 4, half-maximal inhibitory concentration: > 25000 nM
Compound 4: a limit, no number (the forecaster's own chance of this, stated with the estimate: 15%); the middle value does not contradict the limit.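

In this assay compound 4 gives > 25000 nM as a limit of the assay and not as a number. On the core bearing 4-fluorobenzyl, methoxy in place of hydrogen brings an at least 2.3-fold higher number from compound 3 to compound 4 (0.37 log units; beyond the scatter) and so goes the same way as on the core bearing 4-fluorophenyl, although here the entering methoxy sits ortho to a large group and the earlier one does not. The direction of the change therefore carries over between these two cores, on one pair each, while its size on the second core stays unknown and no constant size can be claimed: the same change on two cores in this assay, a 4.4-fold higher number (0.64 log units; beyond the scatter) from compound 2 to compound 1 and an at least 2.3-fold higher number (0.37 log units; beyond the scatter) from compound 3 to compound 4; the limit leaves it open whether they differ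

Every compound shown carries at least two methoxy groups on the aryl ring, so the effect of a single methoxy group, or of a hydroxyl or an amine in its place, remains open. The nitrile is also common to all of them, and the compounds shown say nothing about how a carboxylic acid or an amide at that position would compare, or about whether a longer chain between the core nitrogen and the 4-fluorophenyl ring would continue the difference seen with 4-fluorobenzyl.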